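Swapping methyl for hydrogen on an aromatic nitrogen

The source may report more compounds than this note shows. Statements on the series, on what has been measured and on what is new or still open speak of the compounds shown alone.

Compound 1 `Cn1c(/C=C/C(=O)c2ccccc2)cc(Br)c1Br`: >= 100000 nM (a limit)
Compound 2 `Cn1c(/C=C/C(=O)c2ccc[nH]2)cc(Br)c1Br`: 600 nM
Compound 3 `Cn1c(/C=C/C(=O)c2ccc(O)cc2)cc(Br)c1Br`: >= 100000 nM (a limit)

All three compounds were tested in a functional assay on KB403 cells (Homo sapiens) for cytotoxicity, read by MTT assay, with stated times of 6 h and 48 h; a higher number here means a weaker inhibitor, a lower number a stronger inhibitor. Compound 1 stands at the limit of >= 100000 nM in this assay, at which 2 of the 3 values shown sit, so its entry is a limit and not a number.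

Compound 4 `O=C(/C=C/c1cc(Br)c(Br)[nH]1)c1ccccc1` brings a new change to compound 1: hydrogen in place of methyl on an aromatic nitrogen. Neither measured step touches that methyl. The first, an at least 160-fold lower number from compound 1 to compound 2 (2.22 log units; beyond the scatter), comes from 1H-pyrrol-2-yl in place of phenyl on a carbonyl carbon. It shows that numbers in this small set can shift strongly, but the change lies at another place. The second, a step that the two limits leave unreadable from compound 1 to compound 3, comes from hydroxy in place of hydrogen on an aromatic carbon and offers no size to carry over.

The expectation is therefore a weak one. The entry for compound 1, >= 100000 nM, is a limit, so a readable number for compound 4 could only be a lower one. A modest move toward a lower number is expected, while staying at the limit is about as likely. The expected step is an at least 2.5-fold lower number from compound 1 to compound 4 (0.39 log units; beyond the scatter). For compound 4 the estimated value is 40000 nM, with an expected range from 4000 nM to 100000 nM.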

Compound 4, half-maximal inhibitory concentration: >= 100000 nM
Compound 4 was reported as a limit (the forecaster's own chance of this, stated with the estimate: 50%); middle value at least 2.5-fold (0.39 log units) away from the limit.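

Compound 1 and compound 4 both stand at a limit and not at a number, so no step between them can be read in this assay: the limit of >= 100000 nM in this assay, at which 3 of the 4 values shown sit.

The compounds shown leave open whether hydrogen in place of methyl on the aromatic nitrogen changes the result at all, including in a compound with a readable value, such as compound 2.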